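From 2-nitrophenyl to 3-nitrophenyl in compound 3

The compounds below may be only part of what the source reports. "The series", "measured", "known", "first", "only" and "open" are said of these compounds alone.

Compound 1 `COc1cc(C(=O)c2cn(-c3ccccc3)cc2-c2cccc([N+](=O)[O-])c2)cc(OC)c1OC`: 50 nM
Compound 2 `COc1cc(C(=O)c2cn(-c3ccc(C)cc3)cc2-c2ccccc2[N+](=O)[O-])cc(OC)c1OC`: 65 nM

In a functional assay on MCF7 cells (Homo sapiens) for cytotoxicity, read by MTT assay, with a stated time of 96 h (on this read-out lower numbers stand for stronger inhibition and higher numbers for weaker inhibition), compound 2 gives 65 nM and compound 1 gives 50 nM, so these two values lie within the usual scatter of each other. Compound 3 `COc1cc(C(=O)c2cn(-c3ccc(C)cc3)cc2-c2cccc([N+](=O)[O-])c2)cc(OC)c1OC` has the same atoms as compound 2, joined differently: 3-nitrophenyl in place of 2-nitrophenyl on an aromatic carbon. Among the measured compounds shown here, no measured pair shows this change alone. Compound 1 also carries 3-nitrophenyl and gives 50 nM, so no step beyond the scatter is expected in this assay. The expected step is a 1.4-fold lower number from compound 2 to compound 3 (0.16 log units; within the scatter). For compound 3 the estimated value is 45 nM, within a range from 15 nM to 140 nM.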

Compound 3, half-maximal inhibitory concentration: 210 nM
Compound 3: the middle estimate sits 4.7-fold (0.67 log units) below what was measured; measured number outside the range, above it.
By their numbers in this assay, from the lowest: compounds 1 and 2 (each within the scatter of the next); then compound 3.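

In this assay, the place of the nitro group on this ring matters: 3-nitrophenyl in place of 2-nitrophenyl gives a 3.2-fold higher number from compound 2 to compound 3 (0.51 log units; beyond the scatter). The 3-nitrophenyl group also does not set the number by itself, since methyl in place of hydrogen on an aromatic carbon gives a 4.2-fold higher number from compound 1 to compound 3 (0.62 log units; beyond the scatter). No measurement here explains either step. Still open, on these data alone, is how an aminophenyl group would read at this position. Also open, as far as these compounds go, is whether the methyl step would hold with 2-nitrophenyl in place of 3-nitrophenyl.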